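The compounds below may be only part of what the source reports. "The series", "measured", "known", "first", "only" and "open" are said of these compounds alone.

Working notes on the series.

Of the compounds shown here, two have numbers so far. Compound 1 `C#CCN(CCCCOc1ccc2ccc(=O)oc2c1)Cc1ccc(OC)cc1` gives 1130 nM in an assay on isolated protein for inhibition of Amine oxidase [flavin-containing] B (Homo sapiens), read by fluorescence and Amplex Red, with stated times of 15 min and 20 min; on this read-out lower numbers stand for stronger inhibition and higher numbers for weaker inhibition. Compound 2 `C#CCN(CCCOc1ccc2ccc(=O)oc2c1)Cc1ccc(OC)cc1`, which carries a shorter chain between the amine and the shared core, gives 6080 nM in this assay. Within the data shown here, on these two numbers compound 2 stands as the higher one, and the gap to compound 1 lies beyond the usual scatter of repeated measurements of this kind; no further step between measured compounds is available to set that gap in a wider context.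

The next compound, compound 3 `C#CCN(CCCOc1ccc2ccc(=O)oc2c1)Cc1ccccc1`, keeps the shorter chain of compound 2 and differs from it in one place: hydrogen in place of methoxy on an aromatic carbon. Among the measured compounds shown here, no measured pair shows what this change does in this assay, so the direction is open. A step of modest size is expected, not clearly beyond the scatter in either direction, so the estimate for compound 3 stays near the number of compound 2 while leaving room on both sides. The step from compound 2 to compound 3 is estimated as a 1.4-fold lower number from compound 2 to compound 3 (0.13 log units; within the scatter). For compound 3 the estimate in this assay is 4500 nM, with a range from 1300 nM to 15000 nM.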

Compound 3, half-maximal inhibitory concentration: 3740 nM
The estimate for compound 3 lay 1.2-fold (0.08 log units) above the measured number; measured number inside the range.
By their numbers in this assay, from the lowest: compound 1; then compounds 3 and 2 (each within the scatter of the next).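

Among these compounds, replacing methoxy with hydrogen on the aromatic carbon para to a large group gives the first step at this position in this assay: a 1.6-fold lower number from compound 2 to compound 3 (0.21 log units; within the scatter), which lies within the scatter. On the shorter chain, the 4-methoxybenzyl and benzyl groups therefore cannot be told apart by this read-out, and the methoxy is not required for compound 3 to keep a number in the same range as compound 2, although this rests on a single pair. No measurement at hand bears on why this change leaves the two numbers within the scatter of each other.

This one pair leaves open whether the same change on the longer chain of compound 1 would also stay within the scatter, since no benzyl partner with that chain is shown. It also leaves open whether a fluorine, a chlorine, a trifluoromethyl or a hydroxyl at the same place on the ring, or a chain longer than that of compound 1, would give a step beyond the scatter in either direction.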